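The source may hold more compounds than are shown below. What is called first, only, known or untested is meant among the compounds shown, and "the series" means these compounds.

Measured so far in a functional assay on the whole organism for inhibition, with Rattus norvegicus as the target, read by paw edema, with stated times of 30 min and 3 h, at a dose of 10 mg/kg by the oral route; on this read-out lower numbers stand for less inhibition and higher numbers for more inhibition at the one dose given (going by the name of the read-out):
compound 1 `O=C1N=C(C2C(=O)c3ccccc3C2=O)CC(c2ccccc2[N+](=O)[O-])N1`: 26%
compound 2 `O=C1N=C(C2C(=O)c3ccccc3C2=O)CC(c2ccc([N+](=O)[O-])cc2)N1`: 19%

Two compounds share the core and differ only in the aryl group on the saturated ring carbon. For the measured compounds named here, the single step between them, a number 7 percentage points lower from compound 1 to compound 2 (within the scatter), does not set compound 1 apart from compound 2; the two numbers in this assay sit within the scatter of each other.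

Compound 3 `O=C1N=C(C2C(=O)c3ccccc3C2=O)CC(c2ccc(Cl)cc2)N1` is not yet measured. Its difference from compound 1 is 4-chlorophenyl in place of 2-nitrophenyl on a saturated ring carbon. Going by the values given here, the only measured step that bears on this change is the swap of nitrophenyl positions, a number 7 percentage points lower from compound 1 to compound 2 (within the scatter), which stayed within the scatter. Among the compounds with values here, no measured step replaces a nitro group with chlorine, so nothing in the numbers points to a shift in either direction. The expected step is therefore a number 5 percentage points lower from compound 1 to compound 3 (within the scatter), none beyond the scatter. For compound 3 the estimate in this assay is 21%, with a range from 8% to 34%.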

Compound 3, a percentage reported as inhibition, in the whole organism at one dose (the size of the read-out at that dose, not a potency): 31%
Beside the measured number, compound 3's estimate is 10 percentage points below it; the range from low to high includes it.
By their numbers in this assay, from the lowest: compounds 2, 1 and 3 (each within the scatter of the next, the first and the last beyond it).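

In this assay, the saturated ring carbon carries 4-chlorophenyl in place of 2-nitrophenyl with no step beyond the scatter: a number 5 percentage points higher from compound 1 to compound 3 (within the scatter). Chloro in place of nitro on an aromatic carbon gives the first step in the series beyond the scatter, though a modest one: a number 12 percentage points higher from compound 2 to compound 3 (beyond the scatter). Compound 1 remains within the scatter of both compound 2 and compound 3, so this separation holds for that one pair only.

As far as these compounds go, whether an amine, a methoxy group or a carboxylic acid in place of chloro on that aromatic carbon would sit nearer compound 2 or compound 3 remains open. Nothing available accounts for the step between compound 2 and compound 3.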